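Swapping the aminofluoropyridine for a difluorophenyl ring

The source may hold more compounds than are shown below. What is called first, only, known or untested is meant among the compounds shown, and "the series" means these compounds.

Measured so far:
compound 1, `COc1cc(-c2nc(C(c3ccc(F)cc3)c3ccc(F)cc3)sc2CC(=O)O)ccn1`: 60%
compound 2, `O=C(O)Cc1sc(C(c2ccc(F)cc2)c2ccc(F)cc2)nc1-c1ccnc(N2CCCC2)c1`: 80%
compound 3, `Nc1cc(-c2nc(C(c3ccc(F)cc3)c3ccc(F)cc3)sc2CC(=O)O)cc(F)n1`: 30%

In an in vitro functional assay on HEK285-7 cells for antagonist activity at prostaglandin D2 receptor 2 (Homo sapiens), read by BRET and beta-arrestin recruitment (a higher number here means a larger maximal response, a lower number a smaller maximal response), compound 3 gives the lowest of the three numbers. Its nearest neighbour is compound 1, and the gap is a number 30 percentage points lower from compound 1 to compound 3 (beyond the scatter); the furthest is compound 2, with a number 50 percentage points lower from compound 2 to compound 3 (beyond the scatter). Both steps onto compound 3 point the same way, each beyond the scatter.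

Compound 4, `O=C(O)Cc1sc(C(c2ccc(F)cc2)c2ccc(F)cc2)nc1-c1cc(F)cc(F)c1`, is not yet measured. It differs from compound 3 in one place: 3,5-difluorophenyl in place of 2-amino-6-fluoropyridin-4-yl on an aromatic carbon. Of the measured steps, none exchanges the ring itself; they change only the group on the 2-methoxypyridin-4-yl or 2-(pyrrolidin-1-yl)pyridin-4-yl ring. The steps of a number 20 percentage points higher from compound 1 to compound 2 (beyond the scatter) and a number 30 percentage points lower from compound 1 to compound 3 (beyond the scatter) show that changes at this position move the largest response by modest to large amounts in either direction. Within the data shown here, since compound 3 stands at the bottom of the range, and the new ring resembles none of the measured groups, the author expects a modest rise for compound 4, a number 25 percentage points higher from compound 3 to compound 4 (beyond the scatter), with wide uncertainty. The estimated largest response for compound 4 is therefore 55%, within a range of 30% to 80%.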

Compound 4, largest response reached (reported as efficacy), in percent of the reference or control that the assay uses: 80%
Estimate against measurement, compound 4: 25 percentage points below; low and high end bracket the measured number.
By their numbers in this assay, from the lowest: compound 3; then compound 1; then compounds 2 and 4 (each within the scatter of the next).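

In this assay, among these compounds, the step of a number 50 percentage points higher from compound 3 to compound 4 (beyond the scatter) is the first exchange of the ring itself at this position, and it shows that a six-membered aromatic ring of carbon only, bearing two fluorines, can stand on this aromatic carbon without the low value of the aminofluoropyridine. The step of no change at the digits printed from compound 2 to compound 4 (within the scatter) places the 3,5-difluorophenyl ring level with the 2-(pyrrolidin-1-yl)pyridin-4-yl ring, while the step of a number 20 percentage points higher from compound 1 to compound 4 (beyond the scatter) sets it apart from the 2-methoxypyridin-4-yl ring, so among these compounds a ring nitrogen is not required for the largest response seen at this position. No measurement given here bears on why these rings differ.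

The compounds shown leave open whether the low value of compound 3 goes with its amino group, its fluorine or its ring nitrogen. An unsubstituted phenyl ring, a 2-aminopyridin-4-yl ring without the fluorine and a 3-amino-5-fluorophenyl ring would each help to separate these parts.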